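The source may report more compounds than this note shows. Statements on the series, on what has been measured and on what is new or still open speak of the compounds shown alone.

Compound 1 `Cc1c(OC2CCN(C)CC2)ccc2cc(NC(=O)c3ccc(O)c(CCC(C)C)c3)c(=O)oc12` and compound 2 `Cc1c(OC2CCN(C)CC2)ccc2cc(NC(=O)c3ccc4c(c3)CCC(C)(C)O4)c(=O)oc12` share the same core but carry different groups on it. In a functional assay on SK-BR-3 cells (Homo sapiens) for antiproliferative activity (on this read-out lower numbers stand for stronger inhibition and higher numbers for weaker inhibition), compound 1 gives 600 nM and compound 2 gives 3460 nM. Among the compounds with values here, compound 1 therefore holds the lower of the two numbers so far, and the gap between them lies beyond the usual scatter of repeated measurements.

Compound 3 `Cc1c(OC2CCN(C)CC2)ccc2cc(NC(=O)c3ccc(O)c(Cl)c3)c(=O)oc12` has not yet been measured. It differs from compound 1 in one place, with chloro in place of isopentyl on an aromatic carbon. This position is ortho to a hydroxy group and meta to a large group.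

Within the data shown here, no measured pair isolates a single change, so the data give no direct size for this swap. Among the measured compounds shown here, the two values show only that compounds on this core can differ clearly in this assay. With a single chlorine replacing the whole chain, a moderate loss of inhibition seems more likely than a gain, although this remains a judgement. The expected step is a 2.5-fold higher number from compound 1 to compound 3 (0.40 log units; beyond the scatter), toward a higher number and probably just beyond the scatter. For compound 3 the estimated value is 1500 nM, with an expected range of 450 nM to 5000 nM.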

Compound 3, half-maximal inhibitory concentration: 2300 nM
Compound 3: the middle estimate sits 1.5-fold (0.19 log units) below what was measured, and the stated range covers the measured number.
By their numbers in this assay, from the lowest: compound 1; then compounds 3 and 2 (each within the scatter of the next).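

Within the data shown here, compound 1 and compound 3 form the first pair on the shared core that differs in one place only, so this change now has a direct size: in this assay, putting chloro in place of isopentyl on the aromatic carbon ortho to a hydroxy group gives a 3.8-fold higher number from compound 1 to compound 3 (0.58 log units; beyond the scatter), a modest step. This shows that the position is not indifferent to what sits on it, and that here the isopentyl chain goes with the lower number and so with the stronger inhibition. No measurement shown explains why the swap has this effect or this size.

Among these compounds, with only two groups compared at this position, a single step cannot show whether the number follows chain size or depends on something else about the two groups. The compounds shown leave open how a plain hydrogen, a small methyl group, an ethyl chain or a chain ending in an amine would fare here, and whether any of these would match or improve on isopentyl.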